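A few compounds are considered here, and "the series" means these few. Any claim that something is new, unique, unknown or untested is made for them only; others in the source may bear on it.

Compound 1 `CC(C)(Oc1ccccc1)C1OCC(C/C=C\CCC(=O)O)C(c2cccnc2)O1` gives 75000 nM in an assay for inhibition of prostacyclin synthase (Homo sapiens), using microsomes; on this read-out higher numbers stand for weaker inhibition and lower numbers for stronger inhibition. Compound 2 `CSc1ccc(OC(C)(C)C2OCC(C/C=C\CCC(=O)O)C(c3cccnc3)O2)c([N+](=O)[O-])c1` gives 5000 nM, the lowest of the two plain numbers shown, with compound 1 a 15-fold lower number from compound 1 to compound 2 (1.18 log units; beyond the scatter) away. Compound 3 `CC(C)(Oc1ccccc1F)C1OCC(C/C=C\CCC(=O)O)C(c2cccnc2)O1` reaches only a limit of the assay, < 1000 nM (the limit of < 1000 nM in this assay, at which 1 of the 3 values shown sits). Compound 4 `CC(C)(Oc1ccccc1O)C1OCC(C/C=C\CCC(=O)O)C(c2cccnc2)O1` is not yet measured; from compound 2 the change is a group of 7 heavy atoms (6 carbon, 1 oxygen; one six-membered aromatic ring of carbon only) in place of a group of 11 heavy atoms (7 carbon, 1 nitrogen, 2 oxygen, 1 sulfur; one six-membered aromatic ring of carbon only), on an oxygen on a saturated carbon. Both earlier aryl swaps on that oxygen moved the number strongly, a 15-fold lower number from compound 1 to compound 2 (1.18 log units; beyond the scatter) and an at least 5.0-fold lower number from compound 2 to compound 3 (0.69 log units; beyond the scatter), and fluoro in place of hydrogen gave an at least 75-fold lower number from compound 1 to compound 3 (1.87 log units; beyond the scatter). A 2-hydroxyphenyl is a smaller group than the one it replaces, so a step in either direction is possible; compound 4 is expected to land near compound 2, at about 4000 nM (range 600 nM to 25000 nM), a step of a 1.3-fold lower number from compound 2 to compound 4 (0.10 log units; within the scatter).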

Compound 4, half-maximal inhibitory concentration: > 100000 nM
Compound 4: no number, only a limit; the forecaster's own chance of this, stated with the estimate: 15%; at least 25-fold (1.39 log units) between middle value and limit.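

In this assay the aryl group on this oxygen can push the number up as well as down (an at least 20-fold higher number from compound 2 to compound 4 (1.30 log units; beyond the scatter)), and swapping one group on the same ring, hydroxy in place of fluoro, gives a large step (an at least 100-fold higher number from compound 3 to compound 4 (2.00 log units; beyond the scatter)). Hydroxy in place of hydrogen gives only a floor that does not separate the two compounds (an at least 1.3-fold higher number from compound 1 to compound 4 (0.12 log units; that floor lies within the scatter)). Compound 4 sits at a limit of the assay, not at a number: the limit of > 100000 nM in this assay, at which 1 of the 4 values shown sits. As far as these compounds go, whether a methoxy or an amine in place of the hydroxy would behave like the fluoro stays open. From the compounds shown here alone, neither compound 3 nor compound 4 has a number, so the true gap between them also stays open.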